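This account rests on a few compounds, and the source may have more. Where it says the series, first, only, none or still open, it means among the compounds named here.

Compound 1 `Cc1nc(N)sc1CCCNC(=N)NC(=O)C[C@@H](C)c1ccccc1` gives 73% in a functional assay on cardiac atrium for agonist activity at histamine H2 receptor (Cavia porcellus); on this read-out lower numbers stand for smaller maximal responses and higher numbers for larger maximal responses. Compound 2 `Cc1nc(N)sc1CCCNC(=N)NC(=O)CC(C)c1ccccc1` gives 89%. Compound 3 `Cc1nc(N)sc1CCCNC(=N)NC(=O)C[C@@H](C)C1CCCCC1` gives 80%.

Compound 3 sits between the other two, but only within the scatter: a number 7 percentage points higher from compound 1 to compound 3 (within the scatter) and a number 9 percentage points lower from compound 2 to compound 3 (within the scatter). The step to compound 4 `Cc1nc(N)sc1CCCNC(=N)NC(=O)CC(C)C1CCCCC1` is the two compounds have the same atoms and bonds; at least one stereo element is drawn with a configuration in one of them and without one in the other: 1 of 2 stereo elements differ; a stereocentre at a saturated chain carbon is drawn R in compound 3 and without a configuration in compound 4. For the measured compounds named here, the one measured step of the same kind is a number 16 percentage points higher from compound 1 to compound 2 (beyond the scatter), which bears on it because the fact that one of compounds 1 and 2 is drawn with a defined configuration and the other without, at the place where they differ is exactly the kind of change now made on compound 3. An upward step of comparable size is therefore expected in this assay, so compound 4 is estimated to give 93%, with a range from 82% to 102%; the expected step is a number 13 percentage points higher from compound 3 to compound 4 (beyond the scatter).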

Compound 4, largest response reached (Emax), in percent of the reference or control that the assay uses: 74%
Beside the measured number, compound 4's estimate is 19 percentage points above it; measured number outside the range, below it.
By their numbers in this assay, from the lowest: compounds 1, 4, 3 and 2 (each within the scatter of the next, the first and the last beyond it).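

Dropping the drawn configuration has no fixed effect at this carbon: a number 6 percentage points lower from compound 3 to compound 4 (within the scatter) stands against a number 16 percentage points higher from compound 1 to compound 2 (beyond the scatter). Cyclohexyl in place of phenyl, with no configuration drawn on either compound, gives a number 15 percentage points lower from compound 2 to compound 4 (beyond the scatter), while 1-cyclohexylethyl in place of 1-phenylethyl, which also drops the drawn configuration, gives a number 1 percentage points higher from compound 1 to compound 4 (within the scatter). The outcome of the ring swap therefore depends on the compound carrying it: the same change on two cores in this assay, a number 7 percentage points higher (within the scatter) from compound 1 to compound 3 and a number 15 percentage points lower (beyond the scatter) from compound 2 to compound 4, 22 percentage points apart, beyond the scatter of two such steps.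

The compounds shown leave open what the opposite drawn configuration would give on either ring. They also leave open how a longer chain or an amine at this carbon would read in this assay.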